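From 3-fluorophenyl to 4-(trifluoromethyl)phenyl at an assay limit

This account rests on a few compounds, and the source may have more. Where it says the series, first, only, none or still open, it means among the compounds named here.

Values from a functional assay on HCT-15 cells (Homo sapiens) for inhibition (on this read-out higher numbers stand for weaker inhibition and lower numbers for stronger inhibition), for the measured compounds

- Compound 1 (`Oc1ccccc1-c1cc(-c2cccc(F)c2)cc(-c2ccccc2O)n1`) gives > 50000 nM as a limit
- Compound 2 (`Oc1cccc(-c2cc(-c3cccc(F)c3)cc(-c3ccccc3O)n2)c1`) gives > 50000 nM as a limit
- Compound 3 (`Oc1ccc(-c2cc(-c3cccc(F)c3)cc(-c3ccccc3O)n2)cc1`) gives > 50000 nM as a limit

Compound 1 has only a limit (> 50000 nM) and no exact number. The other two measured compounds share this position (the limit of > 50000 nM in this assay, at which 3 of the 3 values shown sit). Compound 4 (`Oc1ccccc1-c1cc(-c2ccc(C(F)(F)F)cc2)cc(-c2ccccc2O)n1`) keeps the core of compound 1, but carries 4-(trifluoromethyl)phenyl in place of 3-fluorophenyl (4-(trifluoromethyl)phenyl in place of 3-fluorophenyl on an aromatic carbon), on the carbon opposite the ring nitrogen.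

The measured steps only move a hydroxyl around a hydroxyphenyl group (a step that the two limits leave unreadable from compound 1 to compound 2) (a step that the two limits leave unreadable from compound 1 to compound 3) (a step that the two limits leave unreadable from compound 2 to compound 3). None has a readable size, and none changes the 3-fluorophenyl group, so they bear on this change only indirectly. Among the measured compounds shown here, with no measured compound showing a number in this assay, no step beyond the scatter is expected, and no direction can be favoured. The expected step is small (a number no higher from compound 1 to compound 4 (the limit leaves the size open)). Another result reported only as a limit is quite likely. The estimate for compound 4 is (50000 nM), with an expected range of (15000 nM to 100000 nM).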

Compound 4, half-maximal inhibitory concentration: > 50000 nM
Compound 4: a limit, no number; the forecaster's own chance of this, stated with the estimate: 65%; the middle value sits exactly at the limit.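

In this assay compound 4 gives > 50000 nM, which is a limit and not a number. No step between compound 1 and compound 4 can be read, because neither has an exact value: the limit of > 50000 nM in this assay, at which 4 of the 4 values shown sit.

The compounds shown leave open whether 4-(trifluoromethyl)phenyl in place of 3-fluorophenyl, or moving the hydroxyl, changes inhibition at all.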